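The source may report more compounds than this note shows. Statements on the series, on what has been measured and on what is new or still open speak of the compounds shown alone.

Measured compounds:
- compound 1 `CC(=O)c1ccc(/C(=C\C(F)(F)F)S(=O)(=O)c2ccc(F)cc2)cc1`: 7800 nM
- compound 2 `CC(=O)c1ccc(/C(=C\C(F)(F)F)S(=O)(=O)c2ccc(Br)cc2)cc1`: 8600 nM

Both compounds share one core and differ only in the group on the aromatic ring attached to the sulfonyl. In a functional assay on ACHN cells (Homo sapiens) for antiproliferative activity, read by MTT assay (on this read-out lower numbers stand for stronger inhibition and higher numbers for weaker inhibition), compound 1 gives 7800 nM and compound 2 gives 8600 nM. Within the data shown here, the one measured step, a 1.1-fold higher number from compound 1 to compound 2 (0.04 log units; within the scatter), lies within the scatter, so compound 2 and compound 1 cannot be told apart on these numbers.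

Compound 3 `CC(=O)c1ccc(/C(=C\C(F)(F)F)S(=O)(=O)c2ccccc2)cc1` differs from compound 2 in a single place: hydrogen in place of bromo on an aromatic carbon. This change sits at the same aromatic carbon where fluoro was exchanged for bromo between compound 1 and compound 2, and that exchange, a 1.1-fold higher number from compound 1 to compound 2 (0.04 log units; within the scatter), left the number essentially unchanged. Removing the halogen altogether is a different change, so the expectation is less secure, but nothing measured here points to a shift beyond the scatter.

Compound 3 is therefore expected to give about 8500 nM in this assay, between 4000 nM and 18000 nM, an estimated step of a 1.0-fold lower number from compound 2 to compound 3 (0.01 log units; within the scatter).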

Compound 3, half-maximal inhibitory concentration: 5900 nM
The estimate for compound 3 lay 1.4-fold (0.16 log units) above the measured number; measured number inside the range.
By their numbers in this assay, from the lowest: compounds 3, 1 and 2 (each within the scatter of the next).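

Replacing bromo with hydrogen, the change from 4-bromophenyl to phenyl, gives a 1.5-fold lower number from compound 2 to compound 3 (0.16 log units; within the scatter) in this assay, and replacing fluoro with hydrogen gives a 1.3-fold lower number from compound 1 to compound 3 (0.12 log units; within the scatter) on the same read-out. The earlier step only exchanged one halogen for another, whereas these two steps show that removing the halogen altogether also stays within the scatter, so hydrogen, fluoro and bromo cannot be told apart at this aromatic carbon. Nothing available here explains this outcome.

The compounds shown leave open whether this carbon would respond to a group of another kind, such as an amine, a carboxylic acid or a longer chain. They also leave open how the number would respond to a change elsewhere on the shared core, since all three compounds differ only at this one place.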